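This account rests on a few compounds, and the source may have more. Where it says the series, first, only, none or still open, it means among the compounds named here.

Measured compounds in an assay on cells for inhibition of sodium- and chloride-dependent glycine transporter 1 (Homo sapiens); a higher number here means that more compound is needed for the effect, a lower number that less compound is needed:
compound 1 `COc1cc(C(F)(F)F)cc(SC)c1C(=O)NC1(c2ccccc2)CCCN(C)C1` gives 24 nM;
compound 2 `COc1cc(C(F)(F)F)cc(SC)c1C(=O)NC1(c2cccc(F)c2)CCCN(C)C1` gives 48 nM;
compound 3 `COc1cc(C(F)(F)F)cc(SC)c1C(=O)NC1(c2cccc(Cl)c2)CCCN(C)C1` gives 25 nM.

Compound 3 stands second highest of the three numbers; its nearest neighbour is compound 1 and its furthest is compound 2, and both gaps lie within the scatter, so the three measured compounds cannot be set in order on this readout.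

Compound 4 `COc1cccc(C2(NC(=O)c3c(OC)cc(C(F)(F)F)cc3SC)CCCN(C)C2)c1` has not been measured. It differs from compound 3 by methoxy in place of chloro on an aromatic carbon. The measured steps on this aromatic carbon are a 2.0-fold higher number from compound 1 to compound 2 (0.30 log units; within the scatter), a 1.0-fold higher number from compound 1 to compound 3 (0.02 log units; within the scatter) and a 1.9-fold lower number from compound 2 to compound 3 (0.28 log units; within the scatter); none of them moves the number beyond the scatter. Going by the values given here, no measured step exchanges chloro for methoxy, so the change to compound 4 has no direct precedent. Since hydrogen, fluoro and chloro on this aromatic carbon all return numbers within the scatter of one another, a step of no more than the scatter is expected for methoxy as well, with the direction uncertain. Compound 4 is therefore estimated at 35 nM, with a range of 12 nM to 100 nM, which means an expected step of a 1.4-fold higher number from compound 3 to compound 4 (0.15 log units; within the scatter).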

Compound 4, half-maximal effective concentration: 110 nM
Estimate against measurement, compound 4: 3.1-fold (0.50 log units) below, outside the stated range (above it).
By their numbers in this assay, from the lowest: compounds 1, 3 and 2 (each within the scatter of the next); then compound 4.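

In this assay, going by these compounds alone, hydrogen, fluoro and chloro on this aromatic carbon left the number within the scatter, but methoxy is the first group to move it beyond the scatter, and it does so against all three: chloro (a 4.4-fold higher number from compound 3 to compound 4 (0.64 log units; beyond the scatter)), fluoro (a 2.3-fold higher number from compound 2 to compound 4 (0.36 log units; beyond the scatter)) and hydrogen (a 4.6-fold higher number from compound 1 to compound 4 (0.66 log units; beyond the scatter)). The tolerance seen across the three earlier compounds therefore does not extend to every group at this place, although each step is modest. Nothing in the data shown bears on why methoxy behaves differently here.

From the compounds shown here alone, it remains open whether this step is particular to methoxy or also appears with a hydroxy group, an ethoxy group or an amine on the same aromatic carbon. The compounds shown also do not tell whether 3-chlorophenyl to 3-methoxyphenyl gives a similar step on another core.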